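A cyclopropylmethyl group on compound 1

This account rests on a few compounds, and the source may have more. Where it says the series, first, only, none or still open, it means among the compounds named here.

Compound 1 (`Fc1ccc(Nc2cc3[nH]c(Nc4ccc(N5CCNCC5)cn4)nc3cn2)cc1C(F)(F)F`) gives 55% in an ADME assay on microsomes from liver (Mus musculus) for metabolic stability, read by LC-MS, using NADPH, with a stated time of 60 min, tested at 0.1 uM; on this read-out lower numbers stand for a less stable compound and higher numbers for a more stable compound. In this assay, compound 2 (`Fc1ccc(Nc2cc3[nH]c(Nc4cc(N5CCNCC5)ccn4)nc3cn2)cc1C(F)(F)F`) gives 78%. Of these two numbers, compound 1 holds the lower one, and the gap between them lies beyond the usual scatter. Going by the values given here, the two compounds do not differ in only one place, however, so no measured step shows what a single change does here.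

Compound 3 (`Fc1ccc(Nc2cc3[nH]c(Nc4ccc(N5CCN(CC6CC6)CC5)cn4)nc3cn2)cc1C(F)(F)F`) has not yet been measured. It carries cyclopropylmethyl in place of hydrogen on an amine nitrogen in a ring, so piperazin-1-yl becomes 4-(cyclopropylmethyl)piperazin-1-yl: cyclopropylmethyl in place of hydrogen on an amine nitrogen in a ring. Among the compounds with values here, no measured compound shows this change, so the expectation is uncertain and is anchored on compound 1 at 55%. A downward step in this assay is expected, probably somewhat larger than the scatter, although a result within the scatter would not be surprising. The estimated change is a number 15 percentage points lower from compound 1 to compound 3 (beyond the scatter). For compound 3 the expected value is 40%, with an estimated range of 20% to 62%.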

Compound 3, percent of the compound remaining: 41%
Beside the measured number, compound 3's estimate is 1 percentage points below it, within the range that was stated.
By their numbers in this assay, from the lowest: compound 3; then compound 1; then compound 2.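

In this assay, going by these compounds alone, the cyclopropylmethyl group on the amine nitrogen of the piperazine ring gives a number 14 percentage points lower from compound 1 to compound 3 (beyond the scatter) and so supplies the only step here that can be read as one change. Compound 1 and compound 2 differ in more than one place and could not show this, whereas the new step shows that replacing hydrogen at this nitrogen, three ring bonds from the ring atom that bears a large group, is enough on its own to move the percentage of compound remaining. No measurement shown here accounts for the drop, so the step stands as an observation without an explanation.

As far as these compounds go, what stays open is whether a smaller group such as methyl, or a group of another kind such as acetyl or 2-hydroxyethyl, would move the number at this nitrogen in the same direction and by a similar amount, or whether the three-membered ring itself matters. Also open, from the compounds shown here alone, is whether cyclopropylmethyl at the same nitrogen of compound 2 would give a step of similar size, since one step on compound 1 sets no pattern for the other compound.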